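From hydroxyamino to (2-aminophenyl)amino on compound 1

A few compounds are considered here, and "the series" means these few. Any claim that something is new, unique, unknown or untested is made for them only; others in the source may bear on it.

In a functional assay on NCI-H661 cells (Homo sapiens) for antiproliferative activity, read by MTT assay, with a stated time of 72 h (on this read-out higher numbers stand for weaker inhibition and lower numbers for stronger inhibition), compound 1 `O=C(CCCCCCc1nc(-c2ccccc2Cl)no1)NO` gives 10300 nM and sits among close neighbours. Compound 3 `O=C(CCCCCCc1nc(-c2cccs2)no1)NO` reads 9460 nM and compound 2 `O=C(CCCCCCc1nc(-c2cccc([N+](=O)[O-])c2)no1)NO` reads 16100 nM there, both within the usual scatter of compound 1. In compound 4 `Nc1ccccc1NC(=O)CCCCCCc1nc(-c2ccccc2Cl)no1` the change from compound 1 is 2-aminophenyl in place of hydroxy on an amide-type nitrogen with 2-aminophenyl in place of hydroxy on an amide-type nitrogen. Within the data shown here, the one measured step, a 1.1-fold lower number from compound 1 to compound 3 (0.04 log units; within the scatter) and within the scatter, concerns thiophen-2-yl in place of 2-chlorophenyl on an aromatic carbon, so it does not touch this nitrogen. Among the measured compounds shown here, no measured compound carries the new change, and the data give it no direction. A shift no larger than the scatter is therefore the plain expectation in this assay though the uncertainty is wide. The expected change is a 1.2-fold higher number from compound 1 to compound 4 (0.07 log units; within the scatter) as estimated here, with little weight on its direction. For compound 4 the estimated value is 12000 nM with an expected range from 3000 nM to 50000 nM for now.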

Compound 4, half-maximal inhibitory concentration: 8310 nM
The estimate for compound 4 lay 1.4-fold (0.16 log units) above the measured number; measured number inside the range.
By their numbers in this assay, from the lowest: compounds 4, 3, 1 and 2 (each within the scatter of the next).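

In this assay, the swap at the amide-type nitrogen gives a 1.2-fold lower number from compound 1 to compound 4 (0.09 log units; within the scatter) and so stays within the scatter, even though a group carrying a six-membered aromatic ring replaces hydroxy. The earlier step concerned only the aromatic carbon, whereas this result shows that, on the core of compound 1, hydroxyamino can give way to (2-aminophenyl)amino without the number leaving the scatter. Nothing available explains why the two groups read alike.

On these data alone, it remains open whether 2-aminophenyl on this nitrogen would read the same way on the cores of compound 2 and compound 3. Also open, as far as these compounds go, is how a phenyl lacking the amine, or a carboxylic acid in place of hydroxyamino, would read in this assay on this core.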